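The compounds below may be only part of what the source reports. "The series", "measured", "known", "first", "only" and "open" are said of these compounds alone.

Within the data shown here, compound 1 `CCCc1nc2ccccc2c(=O)n1/N=C/c1ccc(Oc2ccc(Cl)c(C)c2)cc1` gives 6.02 in a physicochemical assay for lipophilicity, in phosphate buffer, measured as octanol-water partition (a lower number here means a more polar compound, a higher number a more lipophilic compound), the lowest of the three numbers so far. Compound 2 `O=c1c2ccccc2nc(-c2ccccc2)n1/N=C/c1ccc(Oc2ccc([N+](=O)[O-])cc2)cc1` gives 6.12 in this assay, a number within the scatter of compound 1. Compound 3 `Cc1cc(Oc2ccc(/C=N/n3c(-c4ccccc4)nc4ccccc4c3=O)cc2)ccc1Cl` gives 6.52 in this assay, which stands beyond the scatter above compound 1. Two single-point steps are known: a number 0.50 log units higher from compound 1 to compound 3 (beyond the scatter), and a number 0.40 log units higher from compound 2 to compound 3 (beyond the scatter).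

Compound 4 `CCCc1nc2ccccc2c(=O)n1/N=C/c1ccc(Oc2ccccc2)cc1` is not yet measured. It differs from compound 1 by phenyl in place of 4-chloro-3-methylphenyl on an oxygen on an aromatic ring. Neither measured step covers this exchange. The step from compound 2 to compound 3 sits at the same place, an oxygen on an aromatic ring, but swaps in 4-chloro-3-methylphenyl for 4-nitrophenyl and ran modestly upward; the step to compound 4 takes 4-chloro-3-methylphenyl out again and leaves a bare phenyl with fewer heavy atoms and no chlorine. A downward step beyond the scatter is therefore expected, its size not fixed by any measured pair. The step of a number 1.07 log units lower from compound 1 to compound 4 (beyond the scatter) is the estimate adopted for this change. Compound 4 is expected at 4.95, with a range from 4.4 to 5.5.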

Compound 4, partition coefficient: 5.2
Compound 4: middle estimate off by 0.25 log units, on the low side; low and high end bracket the measured number.
By their numbers in this assay, from the lowest: compound 4; then compounds 1 and 2 (each within the scatter of the next); then compound 3.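

In this assay, among these compounds, the step of a number 0.82 log units lower from compound 1 to compound 4 (beyond the scatter) is the first measured exchange at this position with a bare phenyl on the oxygen, so it gives a reading for 4-chloro-3-methylphenyl against an unsubstituted ring rather than against another substituted one. Together with a number 0.40 log units higher from compound 2 to compound 3 (beyond the scatter), it places the compound carrying 4-chloro-3-methylphenyl on the higher side in both exchanges at this oxygen, although the two steps sit on different shared cores, one with propyl and the other with phenyl on the aromatic carbon. Nothing shown accounts for the size of this step or connects it to any particular feature of the departing group.

On these data alone, the chlorine and the methyl leave together in this exchange, so how the step divides between them remains open, and a phenyl ring carrying only chlorine or only methyl on this oxygen would separate the two. Also open, as far as these compounds go, are how an amine or a carboxylic acid on this ring would read, and whether the exchange to bare phenyl gives a similar step when phenyl replaces propyl on the core.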